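Sulfur and Dichloro Groups Combined: Reading Toward Compound 4

This account rests on a few compounds, and the source may have more. Where it says the series, first, only, none or still open, it means among the compounds named here.

Compound 3 `Nc1cc(N)c2nc(-c3ccccc3)c(Oc3ccc(F)cc3)nc2c1` is the starting point of this step. In a functional assay on SK-MEL-2 cells (Homo sapiens) for inhibition, read by sulforhodamine B assay, with a stated time of 48 h (a lower number here means that less compound is tolerated, a higher number that more compound is tolerated), compound 3 gives < 100000 nM, and this is a limit of the assay rather than a measured number. Compound 1 `Nc1cc(N)c2nc(-c3ccccc3)c(Oc3ccc(Cl)c(Cl)c3)nc2c1` carries a 3,4-dichlorophenoxy group where compound 3 carries 4-fluorophenoxy; in this assay compound 1 gives 89100 nM. Compound 2 `Nc1cc(N)c2nc(-c3ccccc3)c(Sc3ccc(F)cc3)nc2c1` gives < 100000 nM in this assay, again a limit. Because (the limit of < 100000 nM in this assay, at which 2 of the 3 values shown sit), the steps a step that the limit leaves unreadable from compound 1 to compound 2 and a step that the limit leaves unreadable from compound 1 to compound 3 cannot be sized, and the same holds for a step that the two limits leave unreadable from compound 2 to compound 3. Compound 4 `Nc1cc(N)c2nc(-c3ccccc3)c(Sc3ccc(Cl)c(Cl)c3)nc2c1` is the compound not yet measured, and it differs from compound 3 by (3,4-dichlorophenyl)sulfanyl in place of 4-fluorophenoxy on an aromatic carbon. All three measured steps bear on this change, since it combines the oxygen-to-sulfur exchange and the halogen exchange seen among them, yet none of them gives a readable size, so no step beyond the scatter is expected in either direction. Compound 4 is therefore expected to give 60000 nM in this assay, with a range from 20000 nM to 100000 nM. The expected step is then a step that the limit leaves unreadable from compound 3 to compound 4, with a real chance that only a limit is reported.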

Compound 4, concentration lethal to 50% of the cells: < 100000 nM
Compound 4: only a limit was reported (the forecaster's own chance of this, stated with the estimate: 40%); the middle value does not contradict the limit.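

Going by these compounds alone, no step joining compound 4 to compound 1, compound 2 or compound 3 can be read, and all of them run into the same limit: the limit of < 100000 nM in this assay, at which 3 of the 4 values shown sit. The compounds shown leave open whether any of these exchanges shifts the read-out in this assay at all, and in which direction.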